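The source may hold more compounds than are shown below. What is called first, only, known or untested is meant among the compounds shown, and "the series" means these compounds.

Measured so far in a functional assay on K562 cells (Homo sapiens) for antiproliferative activity, with a stated time of 72 h; on this read-out lower numbers stand for stronger inhibition and higher numbers for weaker inhibition
Compound 1 `OC[C@H]1O[C@@H](n2cnc3c(NCc4cccc(F)c4)ncnc32)[C@H](O)[C@@H]1O` gives 7600 nM
Compound 2 `OC[C@H]1O[C@@H](n2cnc3c(NCc4ccccc4Br)ncnc32)[C@H](O)[C@@H]1O` gives 10000 nM
Compound 3 `OC[C@H]1O[C@@H](n2cnc3c(NCc4ccc(Cl)cc4Cl)ncnc32)[C@H](O)[C@@H]1O` gives 106000 nM

Compound 3 stands highest of the three and is the weakest, while a 1.3-fold higher number from compound 1 to compound 2 (0.12 log units; within the scatter) leaves the other two within the scatter of each other. Compound 4 `OC[C@H]1O[C@@H](n2cnc3c(NCc4ccc(F)cc4F)ncnc32)[C@H](O)[C@@H]1O` carries 2,4-difluorophenyl in place of 2,4-dichlorophenyl on a saturated chain carbon bound to a nitrogen on an aromatic ring. Among the compounds with values here, no measured step makes this exchange. The nearest evidence is a 14-fold higher number from compound 1 to compound 3 (1.14 log units; beyond the scatter) and an 11-fold higher number from compound 2 to compound 3 (1.03 log units; beyond the scatter), both large, and both ending at the 2,4-dichlorophenyl group. A sizeable move to a lower number is therefore expected in this assay, probably short of those steps, with a 5.3-fold lower number from compound 3 to compound 4 (0.72 log units; beyond the scatter) as the expected step. Compound 4 is estimated at 20000 nM (6000 nM to 80000 nM).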

Compound 4, half-maximal inhibitory concentration: 9600 nM
For compound 4 the middle estimate is 2.1-fold (0.32 log units) above the measured one; low and high end bracket the measured number.
By their numbers in this assay, from the lowest: compounds 1, 4 and 2 (each within the scatter of the next); then compound 3.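

In this assay the exchange of 2,4-dichlorophenyl for 2,4-difluorophenyl gives an 11-fold lower number from compound 3 to compound 4 (1.04 log units; beyond the scatter) at this place, so the high number goes with the 2,4-dichlorophenyl group and not with the 2,4-difluorophenyl group. The steps of a 1.0-fold lower number from compound 2 to compound 4 (0.02 log units; within the scatter) and a 1.3-fold higher number from compound 1 to compound 4 (0.10 log units; within the scatter) are both small, and among these four only the 2,4-dichlorophenyl group stands apart. Nothing measured here gives a reason for this large step. The compounds shown leave open whether 2-chlorophenyl or 4-chlorophenyl alone would give so high a number, and how a 2,4-dimethoxyphenyl group would read at this place.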